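A few compounds are considered here, and "the series" means these few. Any claim that something is new, unique, unknown or untested is made for them only; others in the source may bear on it.

Measured so far:
- Compound 1 `O=c1[nH]/c(=C\c2nc[nH]c2C2CC2)c(=O)[nH]/c1=C\c1cccc(Oc2ccc(F)cc2)c1`: 15.2 nM
- Compound 2 `Cc1[nH]cnc1/C=c1\[nH]c(=O)/c(=C/c2cccc(Oc3ccc(F)cc3)c2)[nH]c1=O`: 47.6 nM
- Compound 3 `Cc1ccc(/C=c2\[nH]c(=O)/c(=C/c3cccc(Oc4ccc(F)cc4)c3)[nH]c2=O)o1`: 30 nM

In a functional assay on NCI-H460 cells (Homo sapiens) for cytotoxicity, read by MTT assay, with a stated time of 72 h (on this read-out higher numbers stand for weaker inhibition and lower numbers for stronger inhibition), compound 3 gives 30 nM, which lies within the scatter of the values for the other two compounds. The next compound, compound 4 `O=c1[nH]/c(=C\c2nc3ccccc3[nH]2)c(=O)[nH]/c1=C\c1cccc(Oc2ccc(F)cc2)c1`, has 1H-benzimidazol-2-yl in place of 5-methylfuran-2-yl on a double-bonded chain carbon bound to an aromatic carbon.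

The closest evidence comes from two swaps at this same place, a 2.0-fold higher number from compound 1 to compound 3 (0.30 log units; within the scatter) and a 1.6-fold lower number from compound 2 to compound 3 (0.20 log units; within the scatter), and both stay within the scatter. For the measured compounds named here, the only step beyond it, a 3.1-fold higher number from compound 1 to compound 2 (0.50 log units; beyond the scatter), is modest. Going by the values given here, on that basis, no large shift is expected in this assay, although no measured compound carries a six-membered aromatic ring of carbon only at this place, so the uncertainty is wide. The expected change is a 1.3-fold higher number from compound 3 to compound 4 (0.12 log units; within the scatter), which would not be a clear move in either direction. The estimate for compound 4 is 40 nM, with an expected range of 12 nM to 130 nM.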

Compound 4, half-maximal inhibitory concentration: > 1000 nM
Compound 4 ended at the assay's limit; the forecaster's own chance of this, stated with the estimate: 3%; middle value at least 25-fold (1.39 log units) away from the limit.
By their numbers in this assay, from the lowest: compounds 1, 3 and 2 (each within the scatter of the next, the first and the last beyond it). At a limit, above all of these: compound 4.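

Compound 4 stands in this assay only as a limit of the assay, not as a number: the limit of > 1000 nM in this assay, at which 1 of the 4 values shown sits. Until now this place, on a double-bonded chain carbon bound to an aromatic carbon, had carried 5-cyclopropyl-1H-imidazol-4-yl, 5-methyl-1H-imidazol-4-yl and 5-methylfuran-2-yl with no step larger than modest, whereas 1H-benzimidazol-2-yl gives an at least 33-fold higher number from compound 3 to compound 4 (1.52 log units; beyond the scatter) and an at least 21-fold higher number from compound 2 to compound 4 (1.32 log units; beyond the scatter) and an at least 65-fold higher number from compound 1 to compound 4 (1.81 log units; beyond the scatter), all large. The place therefore does not accept every aromatic group, although compound 4 alone cannot separate its six-membered aromatic ring of carbon only from the rest of the change.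

As far as these compounds go, whether a plain phenyl or a pyridine ring here would stay close to compounds 1, 2 and 3 remains open. From the compounds shown here alone, how far compound 4 lies past its limit also remains open.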